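Swapping Cyano for Methylsulfonyloxy on Compound 3

The source may report more compounds than this note shows. Statements on the series, on what has been measured and on what is new or still open speak of the compounds shown alone.

Three measured compounds share one core. Compound 1 `CSc1ccccc1N1CCN(CCCCCC(=O)N2CCc3ccccc3C2)CC1` gives 32.9 nM in an assay on HEK293 cells for displacement of a labelled ligand from 5-hydroxytryptamine receptor 7 (Rattus norvegicus) (a lower number here means a stronger inhibitor, a higher number a weaker inhibitor), compound 2 `CSc1ccccc1N1CCN(CCCCCC(=O)NCc2ccccc2)CC1` gives 22 nM, and compound 3 `CSc1ccccc1N1CCN(CCCCCC(=O)NCc2ccc(C#N)cc2)CC1` gives 9 nM, the lowest of the three numbers; the step of a 2.4-fold lower number from compound 2 to compound 3 (0.39 log units; beyond the scatter) separates it from its nearest neighbour, and the step of a 3.7-fold lower number from compound 1 to compound 3 (0.56 log units; beyond the scatter) is larger still. Compound 4 `CSc1ccccc1N1CCN(CCCCCC(=O)NCc2ccc(OS(C)(=O)=O)cc2)CC1` differs from compound 3 in one place: (methylsulfonyl)oxy in place of cyano on an aromatic carbon. Among the compounds with values here, no measured step exchanges one group for another on that aromatic carbon; only the step of a 2.4-fold lower number from compound 2 to compound 3 (0.39 log units; beyond the scatter), which puts cyano where hydrogen stood, touches the same spot. Going by these compounds, whether the new group keeps that gain is unknown, so compound 4 is expected to show a small step of a 1.7-fold higher number from compound 3 to compound 4 (0.22 log units; within the scatter) toward a higher number, with an estimated value of 15 nM and a range from 5 nM to 45 nM.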

Compound 4, inhibition constant: 148 nM
For compound 4 the middle estimate is 9.9-fold (0.99 log units) below the measured one; measured number outside the range, above it.
By their numbers in this assay, from the lowest: compound 3; then compounds 2 and 1 (each within the scatter of the next); then compound 4.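

This aromatic carbon does not treat every group alike: with (methylsulfonyl)oxy in place of cyano, this assay shows a 16-fold higher number from compound 3 to compound 4 (1.22 log units; beyond the scatter). The new group does more than lose what cyano gained, since replacing hydrogen with it gives a 6.7-fold higher number from compound 2 to compound 4 (0.83 log units; beyond the scatter). Nothing here explains why these groups differ so sharply. Still open, going by these compounds, is how a smaller group with a sulfur-oxygen link, such as methylsulfonyl, or a different group, such as an amine or a carboxylic acid, would read on this carbon. Whether the same exchange would matter on another core also remains unanswered.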